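Swapping the aryl group on the amide nitrogen of compound 2

A few compounds are considered here, and "the series" means these few. Any claim that something is new, unique, unknown or untested is made for them only; others in the source may bear on it.

Measured compounds:
Compound 1, `COC(=O)c1ccc(N(Cc2cnc(C3CCCCC3)cn2)C(=O)[C@H]2CCN2S(=O)(=O)c2c(F)c(F)c(F)c(F)c2F)cc1O`: 1600 nM
Compound 2, `CONC(=O)c1ccc(N(Cc2ccc(C3CCCCC3)cn2)C(=O)[C@H]2CCN2S(=O)(=O)c2c(F)c(F)c(F)c(F)c2F)cc1O`: 6700 nM
Compound 3, `O=C([C@H]1CCN1S(=O)(=O)c1c(F)c(F)c(F)c(F)c1F)N(Cc1ccc(C2CCCCC2)cc1)c1ccc2c(=O)[nH]ncc2c1`: 1600 nM

All three were tested in a functional assay on MDA-MB-231 cells (Homo sapiens) for antiproliferative activity, with a stated time of 72 h; a higher number here means that more compound is needed for the effect, a lower number that less compound is needed. Among them compound 2 stands highest; compound 1 gives 1600 nM and compound 3 gives 1600 nM, both set apart from compound 2 by a gap beyond the usual scatter, so compound 2 needs the most material of the three.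

Compound 4, `O=C([C@H]1CCN1S(=O)(=O)c1c(F)c(F)c(F)c(F)c1F)N(Cc1ccc(C2CCCCC2)cn1)c1ccc2nn[nH]c2c1`, has not yet been measured. It differs from compound 2 in one place: a group of 9 heavy atoms (6 carbon, 3 nitrogen; one five-membered aromatic ring with 3 hetero atoms, one six-membered aromatic ring of carbon only) in place of a group of 12 heavy atoms (8 carbon, 1 nitrogen, 3 oxygen; one six-membered aromatic ring of carbon only), on an amide-type nitrogen. The 3-hydroxy-4-(methoxycarbamoyl)phenyl group leaves, and a smaller group holding a five-membered aromatic ring with three hetero atoms fused to a six-membered carbon ring enters on the amide-type nitrogen.

Among the compounds with values here, no step between two measured compounds covers this exact change. Compound 3, which also carries a two-ring heteroaromatic group at that position, gives 1600 nM, so a downward step is expected, as in a 2.7-fold lower number from compound 2 to compound 4 (0.43 log units; beyond the scatter). Compound 4 is therefore estimated at 2500 nM, within a range from 800 nM to 8000 nM.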

Compound 4, half-maximal effective concentration: 6600 nM
Beside the measured number, compound 4's estimate is 2.6-fold (0.42 log units) below it; the measured number falls inside the stated range.
By their numbers in this assay, from the lowest: compounds 1 and 3 (each within the scatter of the next); then compounds 4 and 2 (each within the scatter of the next).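

In this assay, placing the fused two-ring group on the amide-type nitrogen in place of the 3-hydroxy-4-(methoxycarbamoyl)phenyl group gives a 1.0-fold lower number from compound 2 to compound 4 (0.01 log units; within the scatter), so this pair shows no real change. In this pair, the position tolerates a smaller group with fewer hydrogen-bond donors and acceptors, and the hydroxy and methoxycarbamoyl groups are not needed to keep this level of activity when the fused group takes their place. Nothing available explains why the two groups come out alike.

From the compounds shown here alone, whether either substituent matters on its own stays open: a phenyl carrying only the hydroxy group, or a carboxylic acid in place of the methoxycarbamoyl group, would test this. A single pair in this assay also cannot tell whether the same swap would hold with other groups elsewhere on the core.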